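A few compounds are considered here, and "the series" means these few. Any claim that something is new, unique, unknown or untested is made for them only; others in the source may bear on it.

In a functional assay on HeLa cells (Homo sapiens) for cytotoxicity, read by resazurin assay, with a stated time of 72 h (a higher number here means a weaker inhibitor, a lower number a stronger inhibitor), the dithiocarbonate-type compound 1, `COCCSC(=S)SCC(=O)c1ccc(OC)cc1`, gives 7880 nM, and compound 2, `CCSC(=S)SCC(=O)c1ccc(NS(=O)(=O)c2ccccc2)cc1`, gives 9040 nM. Among the measured compounds shown here, these two values lie within the scatter of each other, so compound 1 stands level with the only other measured compound, and neither can be ranked above the other.

Compound 3, `CCSC(=S)SCC(=O)c1ccc(OC)cc1`, has not yet been measured. It differs from compound 1 in one place: hydrogen in place of methoxy on a saturated chain carbon, two bonds along the chain from a sulfur. Hydrogen stands in place of methoxy on a saturated chain carbon, two bonds along the chain from a sulfur, so the 2-methoxyethyl of compound 1 is cut back to ethyl, while the rest of the core of compound 1 stays as it is.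

For the measured compounds named here, no measured pair shows what this change does, so the data give no size or direction for it. Nothing beyond the scatter is therefore expected in this assay. The estimated step of a 1.1-fold lower number from compound 1 to compound 3 (0.02 log units; within the scatter) is expected to stay within that scatter. For compound 3 the expected value is 7500 nM, with an estimated range of 3000 nM to 18000 nM.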

Compound 3, half-maximal inhibitory concentration: 1960 nM
Compound 3: middle estimate off by 3.8-fold (0.58 log units), on the high side, outside the stated range (below it).
By their numbers in this assay, from the lowest: compound 3; then compounds 1 and 2 (each within the scatter of the next).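

In this assay, cutting the 2-methoxyethyl back to ethyl while the rest of the core of compound 1 stays as it is gives a 4.0-fold lower number from compound 1 to compound 3 (0.60 log units; beyond the scatter) and so shows that the group at this place bears on the number, something compounds 1 and 2 could not show, as they differ in more than one place. The step is modest but lies beyond the scatter, and it runs towards the lower number with hydrogen in place of methoxy on a saturated chain carbon, two bonds along the chain from a sulfur. Nothing in the data explains why the number moves in this way.

Going by these compounds, whether the step follows the loss of the oxygen or the shorter chain stays open, since a propyl or butyl chain, a 2-hydroxyethyl or a 2-aminoethyl at this place could separate the two. On these data alone, it also rests on a single pair, so whether the same change has a similar effect when the methoxy on the other side of the core is replaced by another group remains unknown.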